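This account rests on a few compounds, and the source may have more. Where it says the series, first, only, none or still open, it means among the compounds named here.

Measured compounds and their results:

Compound 1 `FC(F)(F)Oc1ccc(-c2ccc(-c3ccc(-c4nc5ccccc5[nH]4)cc3)cc2)cc1` gives 39100 nM in a functional assay on KB cells (Homo sapiens) for inhibition, read by sulforhodamine B assay; a higher number here means a weaker inhibitor of growth, a lower number a stronger inhibitor of growth.
Compound 2 `Oc1ccc(-c2ccc(-c3ccc(-c4nc5ccccc5[nH]4)cc3)cc2)cc1` gives 41000 nM in this assay.
Compound 3 `Cc1ccc2[nH]c(-c3ccc(-c4ccc(-c5ccc(OC(F)(F)F)cc5)cc4)cc3)nc2c1` gives 41200 nM in this assay.

All three compounds share a chain of three six-membered aromatic rings capped at one end by a fused two-ring system. Compound 2 differs from compound 1 only by hydrogen in place of trifluoromethyl on an oxygen on an aromatic ring, and this change made a step of a 1.0-fold higher number from compound 1 to compound 2 (0.02 log units; within the scatter). Compound 3 differs from compound 1 at the other end of the molecule, by methyl in place of hydrogen on an aromatic carbon, and that change made a step of a 1.1-fold higher number from compound 1 to compound 3 (0.02 log units; within the scatter). All three measured numbers lie within the usual scatter of one another, so none of the three can be called the stronger or weaker inhibitor of growth.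

Compound 4 `Cc1ccc2[nH]c(-c3ccc(-c4ccc(-c5ccc(O)cc5)cc4)cc3)nc2c1` has not been measured. Among the compounds with values here, it differs from compound 3 by hydrogen in place of trifluoromethyl on an oxygen on an aromatic ring, which is the same change as the one from compound 1 to compound 2: the place of the change is described in exactly the same words in both cases. The two cores differ by methyl in place of hydrogen on an aromatic carbon.

For compound 4 the expected step is a 1.0-fold higher number from compound 3 to compound 4 (0.02 log units; within the scatter), set beside the earlier step because a 1.0-fold higher number from compound 1 to compound 2 (0.02 log units; within the scatter) shows that this change left the number essentially unmoved on the other core. Compound 4 is therefore estimated to give about 43000 nM in this assay. For compound 4 the expected range runs from 20000 nM to 90000 nM, reflecting the scatter of such measurements and the small number of examples.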

Compound 4, concentration for 50% growth inhibition: 21200 nM
Compound 4: the middle estimate sits 2.0-fold (0.31 log units) above what was measured; the measured number falls inside the stated range.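

In this assay, putting hydrogen in place of trifluoromethyl on the oxygen gives a 1.9-fold lower number from compound 3 to compound 4 (0.29 log units; within the scatter), and this step cannot be told apart from the same change made on the core of compound 1: the same change on two cores in this assay, a 1.0-fold higher number (0.02 log units; within the scatter) from compound 1 to compound 2 and a 1.9-fold lower number (0.29 log units; within the scatter) from compound 3 to compound 4, 2.0-fold (0.31 log units) apart, within the scatter of two such steps

The methyl on an aromatic carbon gives a 1.9-fold lower number from compound 2 to compound 4 (0.29 log units; within the scatter), and it too reads the same on both of its cores: the same change on two cores in this assay, a 1.1-fold higher number (0.02 log units; within the scatter) from compound 1 to compound 3 and a 1.9-fold lower number (0.29 log units; within the scatter) from compound 2 to compound 4, 2.0-fold (0.31 log units) apart, within the scatter of two such steps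

So each of these two changes carried over from one core to the other as far as this measurement can tell, but every step involved lies within the scatter, and each comparison rests on just two steps, so this does not show that the changes are truly without effect or that they would behave alike on any other core.

The compounds shown leave open whether an amine, a carboxylic acid or a longer chain such as butoxy, placed where the hydroxy or trifluoromethoxy group sits, would move the number by more than the scatter. They also leave open whether a group other than methyl on that aromatic carbon, such as a chlorine atom or a methoxy group, would do so.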